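Swapping the aryl group on the gem-dimethyl side chain

This account rests on a few compounds, and the source may have more. Where it says the series, first, only, none or still open, it means among the compounds named here.

Compound 1 `CC(C)(C)c1ccc(OC(C)(C)C2OCC(C/C=C\CCC(=O)O)C(c3cccnc3)O2)cc1` gives 1910 nM
Compound 2 `CC(C)(Oc1ccccc1[N+](=O)[O-])C1OCC(C/C=C\CCC(=O)O)C(c2cccnc2)O1` gives 11.2 nM
Compound 3 `CC(C)(Oc1ccc(F)cc1[N+](=O)[O-])C1OCC(C/C=C\CCC(=O)O)C(c2cccnc2)O1` gives 2.51 nM

All three values come from a functional assay for inhibition, with Homo sapiens as the target (on this read-out higher numbers stand for weaker binding and lower numbers for tighter binding), and are compared on that scale here. Compound 3 has the lowest of the three numbers, with compound 2 a little higher and compound 1 far higher.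

The next compound, compound 4 `CC(C)(Cc1ccc(F)cc1)C1OCC(C/C=C\CCC(=O)O)C(c2cccnc2)O1`, differs from compound 3 at one place, which is a saturated chain carbon bound to two saturated chain carbons and a saturated ring carbon. The change is a group of 8 heavy atoms (7 carbon, 1 fluorine; one six-membered aromatic ring of carbon only) in place of a group of 11 heavy atoms (6 carbon, 1 nitrogen, 3 oxygen, 1 fluorine; one six-membered aromatic ring of carbon only), on a saturated chain carbon bound to two saturated chain carbons and a saturated ring carbon and the group that enters is 4-fluorobenzyl.

Among the compounds with values here, no measured compound carries this group, so the guidance is indirect. Changing the group at this same place gave large steps: a 170-fold lower number from compound 1 to compound 2 (2.23 log units; beyond the scatter) and a 760-fold lower number from compound 1 to compound 3 (2.88 log units; beyond the scatter) show how far the number can move. Adding fluoro gave only a modest step, a 4.5-fold lower number from compound 2 to compound 3 (0.65 log units; beyond the scatter), and fluorine is counted on both sides of the new change.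

A clear move to a higher number is therefore expected, though its size is uncertain. The expected change is a 20-fold higher number from compound 3 to compound 4 (1.30 log units; beyond the scatter) in this assay and this size is only an estimate. The estimated value for compound 4 is 50 nM, with an expected range from 6 nM to 400 nM.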

Compound 4, dissociation constant: 89.1 nM
Compound 4: middle estimate off by 1.8-fold (0.25 log units), on the low side; the range from low to high includes it.
By their numbers in this assay, from the lowest: compound 3; then compound 2; then compound 4; then compound 1.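

In this assay, 4-fluorobenzyl takes this saturated chain carbon to a middle level, well short of the groups carrying a nitro substituent (a 35-fold higher number from compound 3 to compound 4 (1.55 log units; beyond the scatter); an 8.0-fold higher number from compound 2 to compound 4 (0.90 log units; beyond the scatter)) yet clearly better than 4-(tert-butyl)phenoxy (a 21-fold lower number from compound 1 to compound 4 (1.33 log units; beyond the scatter)). So at this place a nitro substituent is not required for a much lower number than compound 1 gives, although both compounds that carry one still have lower numbers than compound 4. Nothing measured here explains why the number moves with these groups.

The change from compound 3 to compound 4 removes the nitro group and also replaces the phenoxy link with a benzyl link, so the share of each in the step cannot be separated. A 4-fluorophenoxy group would keep the oxygen link without the nitro group, and a 4-fluoro-2-nitrobenzyl group would keep the nitro group without that oxygen, so these two would help to divide the step between the two changes.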